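The source may hold more compounds than are shown below. What is called first, only, known or untested is meant among the compounds shown, and "the series" means these compounds.

Working notes on the series

In a functional assay on HCT-116 cells (Homo sapiens) for inhibition, read by CCK-8 assay, with a stated time of 48 h (a higher number here means a weaker inhibitor, a lower number a stronger inhibitor), compound 3 `COc1cc(-c2ccnc3cc(-c4ccc5c(ccn5C)c4)nn23)cc(OC)c1OC` gives 39 nM, the lowest of the two numbers in hand. Compound 1 `COc1cc(-c2ccnc3cc(-c4cn(CO)c5ccccc45)nn23)cc(OC)c1OC` gives 128 nM in this assay, a gap to compound 3 that lies beyond the usual scatter. Compound 2 `COc1cc(-c2cc3nccc(-c4c[nH]c5ccccc45)n3n2)cc(OC)c1OC` reaches only a limit in this assay, > 10000 nM, and so yields no number to compare; the series thus has (the limit of > 10000 nM in this assay, at which 1 of the 3 values shown sits).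

Compound 4 `COc1ccc(-c2cc3nccc(-c4cc(OC)c(OC)c(OC)c4)n3n2)cc1F` has not yet been measured. It differs from compound 3 in one place: 3-fluoro-4-methoxyphenyl in place of 1-methyl-1H-indol-5-yl on an aromatic carbon. The shared core and the trimethoxyphenyl group stay as they are; only the aryl group on the five-membered ring changes.

Among the measured compounds shown here, no measured pair in the set isolates this kind of change, so the expectation rests on compound 3 alone. A modest loss against compound 3 is expected, with the step from compound 3 to compound 4 in this assay estimated at a 2.8-fold higher number from compound 3 to compound 4 (0.45 log units; beyond the scatter), somewhat beyond the scatter. For compound 4 the value in this assay is estimated at 110 nM, within a range from 30 nM to 400 nM.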

Compound 4, half-maximal inhibitory concentration: 2840 nM
Compound 4: middle estimate off by 26-fold (1.41 log units), on the low side; the measured number lies above the stated range.
By their numbers in this assay, from the lowest: compound 3; then compound 1; then compound 4. At a limit, above all of these: compound 2.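

In this assay the aromatic carbon of the five-membered aromatic ring proves sensitive to the aryl group it carries: 3-fluoro-4-methoxyphenyl in place of 1-methyl-1H-indol-5-yl gives a 73-fold higher number from compound 3 to compound 4 (1.86 log units; beyond the scatter) and is the only single-place step shown in the series. With the shared core and the trimethoxyphenyl group held fixed, this change alone costs most of the activity, although both groups count 0 hydrogen-bond donors and 1 hydrogen-bond acceptor. Nothing measured here gives a cause for the step.

From the compounds shown here alone, whether the loss comes from removing the 1-methyl-1H-indol-5-yl group or from the fluorine and methoxy on the entering phenyl stays open, as this one pair cannot separate them. Also open, going by these compounds, is how a plain phenyl, a 4-methoxyphenyl or a 1H-indol-5-yl group with the ring nitrogen unsubstituted would read at this position.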